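Fluoro for Chloro on the Aryl Piperazine of Compound 1

A few compounds are considered here, and "the series" means these few. Any claim that something is new, unique, unknown or untested is made for them only; others in the source may bear on it.

Measured compounds:
Compound 1 `Nc1ccccc1NC(=O)c1ccc(CSC(=S)N2CCN(c3ccc(Cl)cc3)CC2)cc1`; in a functional assay on MGC-803 cells (Homo sapiens) for antiproliferative activity, read by CCK-8 assay, with a stated time of 72 h, tested at 8 uM (on this read-out lower numbers stand for a weaker effect and higher numbers for a stronger effect at the one concentration tested), compound 1 gives 17.2%
Compound 2 `CCN(Cc1ccncc1)C(=S)SCc1ccc(C(=O)Nc2ccccc2N)cc1`; in this assay compound 2 gives 85.2%
Compound 3 `CN(Cc1cccnc1)C(=S)SCc1ccc(C(=O)Nc2ccccc2N)cc1`; in this assay compound 3 gives 85.5%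

Compound 1 stands lowest of the three numbers in this assay. Its nearest neighbour is compound 2, whose number is higher by a margin beyond the usual scatter, and compound 3 lies higher still by about the same margin. The two higher compounds carry an open-chain amine on the thiocarbonyl carbon, whereas compound 1 carries a piperazine bearing a 4-chlorophenyl group.

Compound 4 `Nc1ccccc1NC(=O)c1ccc(CSC(=S)N2CCN(c3ccc(F)cc3)CC2)cc1` keeps everything of compound 1 except one atom: fluoro in place of chloro on an aromatic carbon.

Among the compounds with values here, the only step measured between two compounds, a number 0.3 percentage points higher from compound 2 to compound 3 (within the scatter), concerns the amine on the thiocarbonyl carbon and is within the scatter. Within the data shown here, it does not touch the halogen on the phenyl ring, so no measured step bears directly on the change from compound 1 to compound 4. The change is small in what is counted, a single halogen for another, and the shared core is unchanged, so in this assay no step beyond the scatter is expected.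

The estimate for compound 4 in this assay is therefore 20%, with a range from 8% to 40%. This estimate means an expected step of a number 2.8 percentage points higher from compound 1 to compound 4 (within the scatter).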

Compound 4, a percentage reported as inhibition, at one concentration (the size of the read-out at that concentration, not a potency): 48.7%
Beside the measured number, compound 4's estimate is 28.7 percentage points below it; the whole stated range lies below it.
By their numbers in this assay, from the lowest: compound 1; then compound 4; then compounds 2 and 3 (each within the scatter of the next).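

In this assay, this halogen is far from a silent detail: fluoro in place of chloro on the aromatic carbon para to a large group gives a number 31.5 percentage points higher from compound 1 to compound 4 (beyond the scatter) even though the rest of compound 1 stays intact. Compounds 2 and 3 carry no 4-chlorophenyl or 4-fluorophenyl group, so they could not show that the read-out responds to a change of a single heavy atom at this position. Nothing at hand bears on why this exchange of halogens has such an effect.

On these data alone, the two halogens alone do not show whether the trend continues to other groups at this position, so it remains open how a bare hydrogen, a methoxy group, an amine or a bromo group would compare with fluoro and chloro. As far as these compounds go, it is also open whether fluoro would have the same effect elsewhere on the phenyl ring, or whether the same exchange would matter in the same way with a different amine on the thiocarbonyl carbon.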